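Thiazole in Place of Phenol on a Silent Scaffold

A few compounds are considered here, and "the series" means these few. Any claim that something is new, unique, unknown or untested is made for them only; others in the source may bear on it.

Of the compounds shown here, three of one shared core have been tested in an assay on cells for inhibition of S-adenosylmethionine decarboxylase proenzyme (Homo sapiens), read by mass spectrometry, at pH 7.2; on this read-out lower numbers stand for stronger inhibition and higher numbers for weaker inhibition. Compound 1 `Cc1cc(Nc2cc(Cl)cc(S(F)(F)(F)(F)F)c2)nc(N)n1` gives only a limit of the assay, > 180000 nM. Compound 2 `COc1ccc(-c2cc(Cl)cc(Nc3cc(C)nc(N)n3)c2)cc1` likewise gives only a limit, > 180000 nM. Compound 3 `Cc1cc(Nc2cc(Cl)cc(-c3ccc(O)cc3)c2)nc(N)n1` also gives only a limit, > 180000 nM. Accordingly the steps a step that the two limits leave unreadable from compound 1 to compound 2, a step that the two limits leave unreadable from compound 1 to compound 3 and a step that the two limits leave unreadable from compound 2 to compound 3 cannot be read, and all three values sit at the limit of > 180000 nM in this assay, at which 3 of the 3 values shown sit.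

Compound 4 `Cc1cc(Nc2cc(Cl)cc(-c3cncs3)c2)nc(N)n1` differs from compound 3 by 1,3-thiazol-5-yl in place of 4-hydroxyphenyl on an aromatic carbon. Among the compounds with values here, no measured step bears on this change, since every value so far is a limit and none of the steps between the measured compounds has a readable size. The account therefore expects that compound 4 will most likely again be reported as a limit in this assay, with the step that the limit leaves unreadable from compound 3 to compound 4 estimated to stay within the scatter of the measurements. The estimate for compound 4 is 200000 nM, with a range from 40000 nM to 1000000 nM.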

Compound 4, half-maximal inhibitory concentration: > 21000 nM
Compound 4: only a limit was reported; the forecaster's own chance of this, stated with the estimate: 75%; the middle value does not contradict the limit.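

Compound 4 is reported only as a limit in this assay, as are compound 1, compound 2 and compound 3, so none of the steps to compound 4 can be read. The compounds shown leave open whether any change on the shared core gives a value that is not a limit.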